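Pyridin-3-yl Replacing Pyrimidin-5-yl on the Thioether Chain

The compounds below may be only part of what the source reports. "The series", "measured", "known", "first", "only" and "open" are said of these compounds alone.

Going by the values given here, compound 2 `CC(Sc1nc2c(cnn2C)c(=O)n1-c1ccccc1)c1cncnc1` gives 100 nM in an assay on isolated protein for inhibition of Retinaldehyde dehydrogenase 3 (Homo sapiens) (on this read-out lower numbers stand for stronger inhibition and higher numbers for weaker inhibition), which places it at the top of the two numbers measured so far, though its only neighbour, compound 1 `CC(Sc1nc2c(cnn2C)c(=O)n1-c1ccccc1)c1ccccc1`, gives 73 nM and the step of a 1.4-fold higher number from compound 1 to compound 2 (0.14 log units; within the scatter) stays within the scatter. Compound 3 `CC(Sc1nc2c(cnn2C)c(=O)n1-c1ccccc1)c1cccnc1` differs from compound 2 by pyridin-3-yl in place of pyrimidin-5-yl on a saturated chain carbon bound to a saturated chain carbon and a sulfur. Among the compounds with values here, the single step that bears on this change, the move a 1.4-fold higher number from compound 1 to compound 2 (0.14 log units; within the scatter), barely shifted the number, so no step beyond the scatter is expected in this assay. Compound 3 is therefore estimated at 85 nM, within 40 nM to 180 nM, an expected step of a 1.2-fold lower number from compound 2 to compound 3 (0.07 log units; within the scatter).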

Compound 3, half-maximal inhibitory concentration: 95 nM
Estimate against measurement, compound 3: 1.1-fold (0.05 log units) below, within the range that was stated.
By their numbers in this assay, from the lowest: compounds 1, 3 and 2 (each within the scatter of the next).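

In this assay the step of a 1.1-fold lower number from compound 2 to compound 3 (0.02 log units; within the scatter) shows no readable difference between pyrimidin-5-yl and pyridin-3-yl on this saturated chain carbon. The step of a 1.3-fold higher number from compound 1 to compound 3 (0.11 log units; within the scatter) adds the comparison with phenyl, so all three aromatic rings at this position now stand within the scatter of one another. No measurement on hand offers an explanation for this.

The compounds shown leave open whether the position would stay this flat with a group of another kind, such as an amine or a carboxylic acid, in place of the aromatic ring.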